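A few compounds are considered here, and "the series" means these few. Any claim that something is new, unique, unknown or untested is made for them only; others in the source may bear on it.

Compound 1 `CC(C(=O)N1CCN(c2ccc(C(F)(F)F)cc2)CC1)N1C(=O)CCC1=O` and compound 2 `CCC(C(=O)N1CCN(c2ccc(C(F)(F)F)cc2)CC1)N1C(=O)CCC1=O` are built on the same core and differ in a single place: methyl in place of hydrogen on a saturated chain carbon, two bonds along the chain from an amide-type nitrogen in a ring and a carbonyl carbon. In a functional assay on the whole organism (strain Swiss) with Mus musculus as the target, in the maximal electroshock model, with a stated time of 2 h, at a dose of 300 mg/kg by the intraperitoneal route (a lower number here means a weaker effect, a higher number a stronger effect of the compound at the dose given), compound 1 gives 0%, and compound 2 gives 0%, so the measured step is no change at the digits printed from compound 1 to compound 2 (within the scatter). Compound 3 `CC(C(=O)N1CCOCC1)N1C(=O)CCC1=O` carries a different core; how the core of compound 3 differs from the core of compound 1 is not broken down here. In this assay compound 3 gives 0%, which is level with compounds 1 and 2. Compound 4 `CCC(C(=O)N1CCOCC1)N1C(=O)CCC1=O` has not yet been measured. For the measured compounds named here, it differs from compound 3 by methyl in place of hydrogen on a saturated chain carbon, two bonds along the chain from an amide-type nitrogen in a ring and a carbonyl carbon, and this is the same change as the one that separates compound 1 from compound 2, made at the same kind of place. The step expected from this change is no change at the digits printed from compound 3 to compound 4 (within the scatter), because the measured pair showed no change at the digits printed from compound 1 to compound 2 (within the scatter), and the starting point in compound 3 is itself at the bottom of the scale. Compound 4 is therefore expected to come out at 0%, with a range from 0% to 10%.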

Compound 4, a percentage reported as activity, at one dose (the size of the read-out at that dose, not a potency): 0%
For compound 4 middle estimate and measured number coincide at the digits printed; low and high end bracket the measured number.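

In this assay, putting methyl in place of hydrogen on this saturated chain carbon gives no change at the digits printed from compound 3 to compound 4 (within the scatter). Set beside the earlier step, the change reads the same on both cores: the same change on two cores in this assay, no change at the digits printed (within the scatter) from compound 1 to compound 2 and no change at the digits printed (within the scatter) from compound 3 to compound 4, 0 percentage points apart, within the scatter of two such steps

This agreement does not show that the change carries an effect from one core to another: compound 1, compound 2, compound 3 and compound 4 all sit at the bottom of the scale, with compound 4 at 0%, and two steps between readings at the bottom of the scale cannot tell what the methyl would do to a compound that shows activity.

The compounds shown leave open whether any member of this series gives a reading above the bottom of the scale at this dose. They also leave open what a different group on the same chain carbon, such as a longer chain, a phenyl group, an amine or a carboxylic acid, would do to that reading.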